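Hydroxy to isopropoxy in the methyl series

The compounds below may be only part of what the source reports. "The series", "measured", "known", "first", "only" and "open" are said of these compounds alone.

Values in a functional assay (Left cardiac atrium, Cavia porcellus), with a stated time of 30 min; on this read-out lower numbers stand for an effect already at smaller amounts and higher numbers for an effect only at larger amounts of compound:
- compound 1 `O=c1onc2n1C=CSC2(O)c1ccccc1`: 6580 nM
- compound 2 `CC1=CSC(O)(c2ccccc2)c2noc(=O)n21`: 230 nM

Compound 2 stands lowest of the two measured compounds, with 230 nM. Compound 3 `CC1=CSC(OC(C)C)(c2ccccc2)c2noc(=O)n21` is not yet measured and differs from it by isopropyl in place of hydrogen on an oxygen on a saturated carbon, that is, hydroxy to isopropoxy. Going by the values given here, the only measured step, a 29-fold lower number from compound 1 to compound 2 (1.46 log units; beyond the scatter), is large but lies on a double-bonded ring carbon, not on this oxygen. It gives no direction for the new change, so no step beyond the scatter is expected in this assay, though with wide uncertainty. The estimated change is a 1.3-fold higher number from compound 2 to compound 3 (0.12 log units; within the scatter). Compound 3 is estimated at 300 nM, with an expected range of 60 nM to 1500 nM.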

Compound 3, half-maximal effective concentration: 1190 nM
Compound 3: middle estimate off by 4.0-fold (0.60 log units), on the low side, within the range that was stated.
By their numbers in this assay, from the lowest: compound 2; then compound 3; then compound 1.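

In this assay, the oxygen on the saturated carbon responds to substitution: isopropyl in place of hydrogen gives a 5.2-fold higher number from compound 2 to compound 3 (0.71 log units; beyond the scatter), a modest step beyond the scatter. In the methyl series, the hydroxy hydrogen therefore cannot be replaced by isopropyl without a change in this read-out. No available data bear on the reason for this step.

Going by these compounds, whether a smaller methoxy group or a longer chain on this oxygen would give a similar step remains open. So does the result of an amine in place of the hydroxy.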